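A few compounds are considered here, and "the series" means these few. Any claim that something is new, unique, unknown or untested is made for them only; others in the source may bear on it.

Compound 1 `CCc1cccc(NC(=O)CN2CCC(c3cccc[n+]3[O-])CC2)c1` and compound 2 `O=C(CN1CCC(c2cccc[n+]2[O-])CC1)Nc1cccc(Cl)c1Cl` share one core and differ only in the aromatic group attached to the amide-type nitrogen. In a functional assay on HEK293 cells for agonist activity at D(4) dopamine receptor (Homo sapiens), read by FLIPR (a lower number here means that less compound is needed, a higher number that more compound is needed for the effect), compound 1 gives 95 nM, while compound 2 gives 180 nM. Within the data shown here, the single measured step, a 1.9-fold higher number from compound 1 to compound 2 (0.28 log units; within the scatter), lies within the scatter, so compound 2 holds the higher of the two numbers without any real separation from compound 1. Compound 3 `Cc1ccc(Cl)cc1NC(=O)CN1CCC(c2cccc[n+]2[O-])CC1` has not yet been measured. It arises from compound 2 through the change (5-chloro-2-methylphenyl in place of 2,3-dichlorophenyl on an amide-type nitrogen). This is again a swap of one aromatic group on the amide-type nitrogen, the same kind of change as the measured step, and that step stayed within the scatter. No shift beyond the scatter is therefore expected, so the step estimated is a 1.2-fold lower number from compound 2 to compound 3 (0.08 log units; within the scatter). Compound 3 is expected to give 150 nM in this assay, with a range from 55 nM to 420 nM.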

Compound 3, half-maximal effective concentration: 126 nM
Beside the measured number, compound 3's estimate is 1.2-fold (0.08 log units) above it; the measured number falls inside the stated range.
By their numbers in this assay, from the lowest: compounds 1, 3 and 2 (each within the scatter of the next).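

In this assay the 5-chloro-2-methylphenyl group gives a 1.4-fold lower number from compound 2 to compound 3 (0.15 log units; within the scatter) and a 1.3-fold higher number from compound 1 to compound 3 (0.12 log units; within the scatter) and so adds a third aromatic group to the series on the amide-type nitrogen. All three compounds now lie within the scatter of one another, including the pair that differs by a 5-chloro-2-methylphenyl and a 3-ethylphenyl group, so these three groups cannot be told apart at this position. The data shown offer no explanation for this result.

The compounds shown carry only six-membered aromatic rings of carbon at this position, so it remains open whether a ring bearing an amine or a carboxylic acid, or a longer chain in place of the ring, would move the number beyond the scatter. They also leave open how far this holds for any other group on the amide-type nitrogen.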